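Series notes: amide aryl exchange from compound 1 to compound 4

The compounds below may be only part of what the source reports. "The series", "measured", "known", "first", "only" and "open" are said of these compounds alone.

Compound 1 is `Cc1ccc(S(=O)(=O)N[C@@H](CC(=O)NC(C)(C)C)C(=O)NCCNC(=O)c2ccccc2)cc1`. In an ADME assay on HepG2 cells (Homo sapiens) for cytotoxicity (a higher number here means that more compound is needed for the effect, a lower number that less compound is needed), compound 1 gives > 11000 nM, which is a limit of the assay and not a number. Compound 2 is `Cc1ccc(S(=O)(=O)N[C@@H](CC(=O)NC(C)(C)C)C(=O)NCCNC(=O)c2ccccc2Cl)cc1`; in this assay compound 2 gives > 11000 nM, again only a limit. Compound 3 is `Cc1ccc(S(=O)(=O)N[C@@H](CC(=O)NC(C)(C)C)C(=O)NCCNC(=O)c2cccc(F)c2)cc1`; in this assay compound 3 gives > 11000 nM, also a limit. The steps a step that the two limits leave unreadable from compound 1 to compound 2, a step that the two limits leave unreadable from compound 1 to compound 3 and a step that the two limits leave unreadable from compound 2 to compound 3 are therefore unreadable in size and direction, because of the limit of > 11000 nM in this assay, at which 3 of the 3 values shown sit.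

Compound 4 is `Cc1ccc(S(=O)(=O)N[C@@H](CC(=O)NC(C)(C)C)C(=O)NCCNC(=O)c2cc(C)ccn2)cc1`. Against compound 1 the change is 4-methylpyridin-2-yl in place of phenyl on a carbonyl carbon. The measured steps that bear on it are the aryl substitutions above, all of which stay at the limit, so none gives a readable size; nothing in the measured set reaches a numeric value from which a direction could be taken.

For compound 4 in this assay the expectation is thus another limit rather than a number, and the expected step that the limit leaves unreadable from compound 1 to compound 4 is read as none beyond the scatter. The estimated value for compound 4 is 15000 nM, with an expected range from 8000 nM to 40000 nM.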

Compound 4, half-maximal effective concentration: > 11000 nM
Compound 4 ended at the assay's limit; the forecaster's own chance of this, stated with the estimate: 85%; the middle value is on the limit's open side.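

In this assay no step from compound 1, compound 2 or compound 3 to compound 4 can be read in size or direction, because all four compounds stand at one limit of the assay: the limit of > 11000 nM in this assay, at which 4 of the 4 values shown sit.

The compounds shown leave open whether any aryl exchange on the carbonyl carbon alters the concentration needed for the effect in this assay.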